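The source may report more compounds than this note shows. Statements on the series, on what has been measured and on what is new or still open speak of the compounds shown alone.

Measured in an ADME assay on L02 cells (Homo sapiens) for cytotoxicity, read by MTT assay, with a stated time of 48 h; on this read-out lower numbers stand for stronger inhibition and higher numbers for weaker inhibition:
- compound 1 `CCN(CC)CCNC(=O)c1ccc(C(CC)(CC)c2ccc(OCC(=O)C(C)(C)C)c(C)c2)n1CC`: 2500 nM
- compound 2 `CCn1c(C(=O)NCCCN(C)C)ccc1C(CC)(CC)c1ccc(OCC(=O)C(C)(C)C)c(C)c1`: 670 nM
- compound 3 `CCN(CC)CCCNC(=O)c1ccc(C(CC)(CC)c2ccc(OCC(=O)C(C)(C)C)c(C)c2)n1CC`: 2300 nM

Compound 3 cannot be told apart from compound 1, with a 1.1-fold lower number from compound 1 to compound 3 (0.04 log units; within the scatter). The clear gap on the numbers is to compound 2, with a 3.4-fold higher number from compound 2 to compound 3 (0.54 log units; beyond the scatter).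

The unmeasured compound 4 `CCn1c(C(=O)NCCN)ccc1C(CC)(CC)c1ccc(OCC(=O)C(C)(C)C)c(C)c1` carries amino in place of (diethylamino)methyl on a saturated chain carbon, two bonds along the chain from an amide-type nitrogen.

Two kinds of measured step bear on this change. With the chain length unchanged, the swap between the two amine ends gave a modest step, a 3.4-fold higher number from compound 2 to compound 3 (0.54 log units; beyond the scatter). The step of a 3.7-fold lower number from compound 1 to compound 2 (0.57 log units; beyond the scatter) is of similar size and runs the same way. Within the data shown here, no compound with an unsubstituted amino end has been measured, so this is an extrapolation. A modest step to a lower number is expected in this assay, though a result within the scatter remains possible.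

The expected step is a 2.9-fold lower number from compound 3 to compound 4 (0.46 log units; beyond the scatter).

For compound 4 the estimate is 800 nM, with an expected range of 250 nM to 2500 nM.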

Compound 4, half-maximal inhibitory concentration: 2500 nM
Compound 4: middle estimate off by 3.1-fold (0.49 log units), on the low side, and the stated range covers the measured number.
By their numbers in this assay, from the lowest: compound 2; then compounds 3, 1 and 4 (each within the scatter of the next).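

In this assay an unsubstituted amino end does not separate from the diethylamino ends: a 1.1-fold higher number from compound 3 to compound 4 (0.04 log units; within the scatter), and no change at the digits printed from compound 1 to compound 4 (within the scatter). Even the large cut from 3-(diethylamino)propyl to 2-aminoethyl therefore leaves the number among those of the diethylamino compounds, so the size of the group at this place does not order the series. Among these compounds, compound 2 goes against any such ordering and remains the only compound apart from the others, with a 3.7-fold higher number from compound 2 to compound 4 (0.57 log units; beyond the scatter).

No measurement shown explains why compound 2 stands apart. Still open, on these data alone, is whether a 3-aminopropyl or a 2-(dimethylamino)ethyl chain would fall with compound 2 or with compounds 1, 3 and 4, which would help separate chain length from the identity of the amine end.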